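Replacing 4-chlorophenyl with 3-hydroxyphenyl: compound 3 to compound 4

The source may report more compounds than this note shows. Statements on the series, on what has been measured and on what is new or still open speak of the compounds shown alone.

Of the compounds shown here, three have been read in a functional assay on HT-29 cells (Homo sapiens) for antiproliferative activity, read by MTT assay, with a stated time of 24 h; on this read-out higher numbers stand for weaker inhibition and lower numbers for stronger inhibition. Compound 1 (`COc1ccc(/C=C/C(=O)c2ccc(OC)c3c2OC(C)(C)C=C3)cn1`) gives > 10000 nM, which is a limit. Among the measured compounds shown here, compound 2 (`COc1ccc(C(=O)/C=C/c2ccccn2)c2c1C=CC(C)(C)O2`) gives 2120 nM, the only true number so far. Compound 3 (`COc1ccc(C(=O)/C=C/c2ccc(Cl)cc2)c2c1C=CC(C)(C)O2`) gives > 10000 nM, which is also a limit, so its position is bounded but not known.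

The next change gives compound 4 (`COc1ccc(C(=O)/C=C/c2cccc(O)c2)c2c1C=CC(C)(C)O2`), with 3-hydroxyphenyl in place of 4-chlorophenyl on a double-bonded chain carbon bound to a double-bonded chain carbon.

Two steps at this place can be read, an at least 4.7-fold lower number from compound 1 to compound 2 (0.67 log units; beyond the scatter) and an at least 4.7-fold higher number from compound 2 to compound 3 (0.67 log units; beyond the scatter). Both lie beyond the scatter, and each is bounded by a limit. The third, a step that the two limits leave unreadable from compound 1 to compound 3, cannot be read. For the measured compounds named here, no measured compound carries 3-hydroxyphenyl, so these steps show only that a swap here can move the value. A modest move to a lower number is expected, with a real chance of remaining at the limit. The estimated step is an at least 2.5-fold lower number from compound 3 to compound 4 (0.39 log units; beyond the scatter). Compound 4 is expected at 4000 nM, with an estimated range of 800 nM to 10000 nM.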

Compound 4, half-maximal inhibitory concentration: > 10000 nM
Compound 4: a limit, no number; the forecaster's own chance of this, stated with the estimate: 40%; at least 2.5-fold (0.39 log units) between middle value and limit.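

The change to 3-hydroxyphenyl on a double-bonded chain carbon bound to a double-bonded chain carbon gives no readable value in this assay, so a hydroxyl-bearing phenyl here does no more to bring a number than 4-chlorophenyl did. Pyridin-2-yl remains the only group at this place with a true value, and the new comparison sets it apart from a second phenyl group, with an at least 4.7-fold higher number from compound 2 to compound 4 (0.67 log units; beyond the scatter). The steps to compound 4 from compound 3 and from compound 1 cannot be read, with both ends of each resting on one limit: the limit of > 10000 nM in this assay, at which 3 of the 4 values shown sit.

As far as these compounds go, whether the value of compound 2 is particular to pyridin-2-yl stays open, and pyridin-3-yl or 3-aminophenyl at this place would test that. From the compounds shown here alone, how far compound 1, compound 3 and compound 4 lie from one another also remains unknown.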